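This account rests on a few compounds, and the source may have more. Where it says the series, first, only, none or still open, it means among the compounds named here.

Measured so far in a functional assay on HepG2 cells (Homo sapiens) for inhibition, read by MTT assay, with a stated time of 48 h, tested at 2 uM; on this read-out lower numbers stand for less inhibition and higher numbers for more inhibition at the one concentration tested (going by the name of the read-out):
compound 1 `Cc1noc(C)c1-c1ccc2c(c1)C(c1ccccc1)N(Cc1nnc(-c3ccccc3)o1)C(=O)N2C`, 34.7%
compound 2 `Cc1nc(-c2ccccc2)sc1CN1C(=O)N(C)c2ccc(-c3c(C)noc3C)cc2C1c1ccccc1`, 29.2%
compound 3 `Cc1noc(C)c1-c1ccc2c(c1)C(c1ccccc1)N(Cc1nnc(-c3ccccc3)s1)C(=O)N2C`, 35.2%

Compound 3 holds the highest of the three numbers, but both steps towards it, a number 0.5 percentage points higher from compound 1 to compound 3 (within the scatter) and a number 6 percentage points higher from compound 2 to compound 3 (within the scatter), lie within the scatter, so the three compounds are not separated in this assay.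

Compound 4 `Cc1noc(C)c1-c1ccc2c(c1)C(c1ccccc1)N(Cc1nc(-c3ccc(F)cc3)cs1)C(=O)N2C` is not yet measured. It differs from compound 3 in one place:
4-(4-fluorophenyl)-1,3-thiazol-2-yl in place of 5-phenyl-1,3,4-thiadiazol-2-yl on a saturated chain carbon bound to an amide-type nitrogen in a ring

All three measured steps concern this same position, each an exchange of one aryl-bearing five-membered heteroaryl group for another: a number 5.5 percentage points lower from compound 1 to compound 2 (within the scatter), a number 0.5 percentage points higher from compound 1 to compound 3 (within the scatter) and a number 6 percentage points higher from compound 2 to compound 3 (within the scatter). None of them moved the number beyond the scatter. The change to compound 4 is an exchange of the same kind at the same place, so no step beyond the scatter is expected in this assay. Compound 4 is expected to give 33%, in the range 22% to 45%. The expected step is a number 2.2 percentage points lower from compound 3 to compound 4 (within the scatter), within the scatter.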

Compound 4, a percentage reported as inhibition, at one concentration (the size of the read-out at that concentration, not a potency): 41.1%
Estimate against measurement, compound 4: 8.1 percentage points below, within the range that was stated.
By their numbers in this assay, from the lowest: compounds 2, 1, 3 and 4 (each within the scatter of the next, the first and the last beyond it).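

a number 11.9 percentage points higher from compound 2 to compound 4 (beyond the scatter) in this assay is the first step at this position to pass the scatter, so the group on the saturated chain carbon can move the number. The reach of this change is limited: a number 5.9 percentage points higher from compound 3 to compound 4 (within the scatter) and a number 6.4 percentage points higher from compound 1 to compound 4 (within the scatter) leave compound 4 unseparated from compound 3 and compound 1, and only compound 2 stands apart from it. No measurement on hand accounts for the step.

The step from compound 2 to compound 4 alters the ring, its point of attachment, the methyl and the fluorine together, so the compounds shown cannot assign it to any one of these. Also open, from the compounds shown here alone, is how a non-aromatic group at this place, such as an amine or a carboxylic acid, would read out.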